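A coumarin-bearing pyrazoline and a swap at its acyl group

The compounds below may be only part of what the source reports. "The series", "measured", "known", "first", "only" and "open" are said of these compounds alone.

Of the compounds shown here, three have been tested in a functional assay on HepG2 cells (Homo sapiens) for cytotoxicity, read by MTT assay, with a stated time of 48 h; on this read-out higher numbers stand for weaker inhibition and lower numbers for stronger inhibition. Compound 1, with the structure `CC1=NN(C(=O)COc2ccc(Cl)cc2)C(c2cc(Br)ccc2O)C1`, is recorded in this assay as "not active" (no number reported). Compound 2, with the structure `CC1=NN(S(=O)(=O)c2ccc([N+](=O)[O-])cc2)C(c2cc(Br)cc(Br)c2O)C1`, is likewise recorded in this assay as "not active" (no number reported). Only compound 3, with the structure `Cc1ccc(C(=O)N2N=C(c3cc4ccccc4oc3=O)CC2c2ccccc2)cc1`, comes with a number: in this assay compound 3 gives 52300 nM, a high concentration that points to weak inhibition of the cells, and it is the only quantified entry, so no ranking among the three can be drawn.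

Compound 4, with the structure `O=C(CNC1CCCCC1)N1N=C(c2cc3ccccc3oc2=O)CC1c1ccccc1`, has not been measured. It differs from compound 3 in one place: (cyclohexylamino)methyl in place of 4-methylphenyl on a carbonyl carbon. For the measured compounds named here, no pair of measured compounds shows what such a change does here, so nothing in the data says which way the number should move. The expectation is therefore a step from compound 3 to compound 4 of a 1.2-fold lower number from compound 3 to compound 4 (0.07 log units; within the scatter), no larger than the usual scatter. Compound 4 is estimated to give 45000 nM, within a range from 12000 nM to 160000 nM.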

Compound 4, half-maximal inhibitory concentration: 34400 nM
Beside the measured number, compound 4's estimate is 1.3-fold (0.12 log units) above it; measured number inside the range.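

For the compounds shown here, this is the first step that can be read at this position: in this assay putting (cyclohexylamino)methyl in place of 4-methylphenyl on a carbonyl carbon gives a 1.5-fold lower number from compound 3 to compound 4 (0.18 log units; within the scatter) so the two compounds cannot be told apart. For this one pair, then, exchanging a six-membered aromatic ring for a non-aromatic one, while adding a nitrogen that brings a hydrogen-bond donor and a hydrogen-bond acceptor, leaves the reading within the usual scatter. Nothing available explains why the two readings stay so close.

The ring and the nitrogen changed together, so the compounds shown cannot separate what each contributes. They also leave open whether a carboxylic acid or a longer unbranched carbon chain on that carbonyl carbon would move the number beyond the scatter.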